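Rearranging the Chloroaryl Ether Toward a Second Ring Substituent

This account rests on a few compounds, and the source may have more. Where it says the series, first, only, none or still open, it means among the compounds named here.

Compound 2 `CCc1nc2ccccc2n1CCCCOc1ccccc1Cl` gives 16 uM in an ADME assay on Vero cells (Chlorocebus sabaeus) for cytotoxicity, read by luminescence, with a stated time of 2 days (on this read-out lower numbers stand for higher toxicity in this test and higher numbers for lower toxicity in this test), the smaller of the two numbers recorded, though its gap to compound 1 `CCc1nc2ccccc2n1CCCCOc1ccccc1C(C)C`, which gives 19 uM, lies within the scatter as the step of a 1.2-fold lower number from compound 1 to compound 2 (0.07 log units; within the scatter) shows. Compound 3 `CCc1nc2ccccc2n1CCCCOc1ccc(C)c(Cl)c1` differs from compound 2 by 3-chloro-4-methylphenyl in place of 2-chlorophenyl on an oxygen on a saturated carbon. Within the data shown here, the one measured step concerned a different change and stayed within the scatter, so it gives little guidance. Compound 3 is therefore expected to show no step beyond the scatter, no change at the digits printed from compound 2 to compound 3 (within the scatter), in this assay. Compound 3 is estimated at 16 uM, with a range of 8 uM to 32 uM.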

Compound 3, half-maximal toxic concentration: 14 uM
For compound 3 the middle estimate is 1.1-fold (0.06 log units) above the measured one, within the range that was stated.
By their numbers in this assay, from the lowest: compounds 3, 2 and 1 (each within the scatter of the next).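

In this assay, the swap of 2-chlorophenyl for 3-chloro-4-methylphenyl on the oxygen gives a 1.1-fold lower number from compound 2 to compound 3 (0.06 log units; within the scatter), so this position has now taken a phenyl ring with a second substituent without a step beyond the scatter. The swap alters the ring in more than one way, and the compounds shown cannot separate the contribution of the methyl from that of the chlorine's placement. Nothing available accounts for this result.

From the compounds shown here alone, it remains open whether an amine or a carboxylic acid on this phenyl ring would produce a step beyond the scatter in this assay. Also open, going by these compounds, is whether the methyl alone, without the chlorine, would keep the number within the scatter.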